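The source may hold more compounds than are shown below. What is called first, only, known or untested is meant among the compounds shown, and "the series" means these compounds.

For the measured compounds named here, compound 3 `CC/C(=C(/c1ccc(/C=C/C(=O)O)cc1)c1cc2ccccc2[nH]1)c1ccc(Cl)cc1Cl` gives 11 nM in a functional assay on MCF7 cells (Homo sapiens) for inhibition (on this read-out lower numbers stand for stronger inhibition and higher numbers for weaker inhibition), the lowest of the three numbers measured so far; compound 2 `CC/C(=C(/c1ccc(/C=C/C(=O)O)cc1)c1cc2ccccc2[nH]1)c1ccc(OC)cc1` gives 61 nM and compound 1 `CC/C(=C(/c1ccc(/C=C/C(=O)O)cc1)c1cc2ccccc2[nH]1)c1ccc(Cl)cc1` gives 343 nM in this assay. Compound 4 `CC/C(=C(/c1ccc(/C=C/C(=O)O)cc1)c1cc2ccccc2[nH]1)c1ccc(Cl)cc1C#N` differs from compound 3 by cyano in place of chloro on an aromatic carbon. Going by the values given here, no measured step swaps chloro for cyano. The step that bears on this position is a 31-fold lower number from compound 1 to compound 3 (1.49 log units; beyond the scatter), which shows a substituent there carries much of the gain; a 5.6-fold lower number from compound 1 to compound 2 (0.75 log units; beyond the scatter) and a 5.5-fold lower number from compound 2 to compound 3 (0.74 log units; beyond the scatter) concern other changes. On these data alone, whether cyano holds what chloro gave is untested, so a modest loss is expected, a 2.3-fold higher number from compound 3 to compound 4 (0.36 log units; beyond the scatter). Compound 4 is therefore estimated at 25 nM, with a range of 8 nM to 80 nM.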

Compound 4, half-maximal inhibitory concentration: 14 nM
Compound 4: middle estimate off by 1.8-fold (0.25 log units), on the high side; measured number inside the range.
By their numbers in this assay, from the lowest: compounds 3 and 4 (each within the scatter of the next); then compound 2; then compound 1.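

Cyano serves at this position as well as chloro: a 1.3-fold higher number from compound 3 to compound 4 (0.10 log units; within the scatter), so the gain is not tied to chloro, even though cyano brings a second heavy atom and a hydrogen-bond acceptor. Against hydrogen, the step is still large, a 25-fold lower number from compound 1 to compound 4 (1.39 log units; beyond the scatter), and the 4-chloro-2-cyanophenyl group also improves on 4-methoxyphenyl, a 4.4-fold lower number from compound 2 to compound 4 (0.64 log units; beyond the scatter), in this assay. No available evidence explains these readings.

On these data alone, whether a methyl, a methoxy or an amine at this position would hold the number stays open. So does whether the cyano gain survives with methoxy in place of the 4-chloro group.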